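From compound 1 to compound 3: one added hydroxy

The source may hold more compounds than are shown below. What is called first, only, known or untested is meant among the compounds shown, and "the series" means these compounds.

Among the compounds with values here, in a functional assay on MCF7 cells (Homo sapiens) for antiproliferative activity, read by MTT assay, with a stated time of 48 h (a higher number here means a weaker inhibitor, a lower number a stronger inhibitor), compound 1 (`COc1ccc(-c2c(Nc3ccc(C)cc3)c3ccccc3oc2=O)cc1`) gives 65300 nM as the only actual number at hand. Compound 2 (`COc1ccc(-c2c(Nc3ccc(NC(C)=O)cc3)c3ccccc3oc2=O)cc1`) reads > 100000 nM and that is a limit of the assay, not a number. Compound 3 (`COc1ccc(-c2c(Nc3ccc(C)cc3)c3ccc(O)cc3oc2=O)cc1`) differs from compound 1 by hydroxy in place of hydrogen on an aromatic carbon and the change is hydroxy in place of hydrogen on an aromatic carbon, in a six-membered aromatic ring of carbon only that is part of a fused or bridged system of two rings. Within the data shown here, the one measured step (an at least 1.5-fold higher number from compound 1 to compound 2 (0.18 log units; that floor lies within the scatter)) exchanges methyl for acetamido, a different change, so it gives no direct guide to an added hydroxy. In this assay no step beyond the scatter is therefore expected. The expected step is a 1.2-fold lower number from compound 1 to compound 3 (0.07 log units; within the scatter) by this estimate. The estimate for compound 3 is 55000 nM as the expected value, with 20000 nM to 100000 nM as its range.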

Compound 3, half-maximal inhibitory concentration: 85500 nM
Compound 3: middle estimate off by 1.6-fold (0.19 log units), on the low side, and the stated range covers the measured number.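

In this assay, hydroxy in place of hydrogen, on an aromatic carbon of a six-membered aromatic ring of carbon only that is part of a fused or bridged system of two rings, gives a 1.3-fold higher number from compound 1 to compound 3 (0.12 log units; within the scatter). Within the data shown here, this is the first reading of any change on this ring, and it shows that adding hydroxy here brings no step beyond the scatter, which the earlier pair, altered only where acetamido replaces methyl, could not show. Compound 3 still gives an actual number, but the scale offers limited room for weaker readings: the limit of > 100000 nM in this assay, at which 1 of the 3 values shown sits.

The compounds shown leave open whether an amine or a carboxylic acid in this same place would read differently from hydroxy. They also leave open how hydroxy would behave on the other carbons of this ring.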